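Shortening the hydroxycarbamoyl chain of compound 1

This account rests on a few compounds, and the source may have more. Where it says the series, first, only, none or still open, it means among the compounds named here.

Of the compounds shown here, three sharing one core have been measured in a functional assay on A549 cells (Homo sapiens) for inhibition; a lower number here means a stronger inhibitor, a higher number a weaker inhibitor. Compound 1 (`CC(C)c1cc(-c2n[nH]c(=O)n2-c2cccc(C(=O)NCCCCCC(=O)NO)c2)c(O)cc1O`) gives 4600 nM, level with compound 2 (`CC(C)c1cc(-c2n[nH]c(=O)n2-c2ccc(C(=O)NCCCCCCC(=O)NO)cc2)c(O)cc1O`) at 4600 nM, and the two sit at the top of the numbers seen so far. Compound 3 (`CC(C)c1cc(-c2n[nH]c(=O)n2-c2cccc(NC(=O)CCCCCCC(=O)NO)c2)c(O)cc1O`) reads lower at 1600 nM, a gap from compound 1 that lies beyond the usual scatter.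

The next compound to be tested, compound 4 (`CC(C)c1cc(-c2n[nH]c(=O)n2-c2cccc(C(=O)NCCCCC(=O)NO)c2)c(O)cc1O`), departs from compound 1 in one place only: hydroxycarbamoyl in place of (hydroxycarbamoyl)methyl on a saturated chain carbon, four bonds along the chain from an amide-type nitrogen. This puts hydroxycarbamoyl in place of (hydroxycarbamoyl)methyl on a saturated chain carbon, four bonds along the chain from an amide-type nitrogen.

Going by the values given here, no two measured compounds differ in a single place, so this assay offers no direct precedent for this change. The measured values also span a narrow range, from compound 3 at 1600 nM to compound 1 at 4600 nM, so no large step is expected. A small move toward a weaker number is the likeliest outcome, and it may not clear the scatter. The expected step is a 1.3-fold higher number from compound 1 to compound 4 (0.12 log units; within the scatter). For compound 4 the estimated value is 6000 nM, with an expected range from 2500 nM to 15000 nM.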

Compound 4, half-maximal inhibitory concentration: 4600 nM
Compound 4: the middle estimate sits 1.3-fold (0.12 log units) above what was measured; the measured number falls inside the stated range.
By their numbers in this assay, from the lowest: compound 3; then compounds 1, 2 and 4 (each within the scatter of the next).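

Going by these compounds alone, replacing (hydroxycarbamoyl)methyl with hydroxycarbamoyl on a saturated chain carbon, four bonds along the chain from an amide-type nitrogen, gives in this assay no change at the digits printed from compound 1 to compound 4 (within the scatter), the first single-place comparison. Read one bond further out, the same difference is 4-(hydroxycarbamoyl)butyl to 3-(hydroxycarbamoyl)propyl, so at this position in the core of compound 1, this assay tolerates the change in chain length without a readable shift. No other data bear on this result, so it remains an observation without an explanation.

Within the data shown here, this single step covers only this one pair, and compound 2 and compound 3 remain joined to the others by no single-place step, so what separates their values cannot be read. From the compounds shown here alone, it remains open how this assay would respond to a still shorter chain ending in hydroxycarbamoyl, to a longer chain such as 5-(hydroxycarbamoyl)pentyl, or to a carboxylic acid or an amine in place of the hydroxycarbamoyl group.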